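Swapping the Ring Nitrogen Substituent of Compound 2

The source may hold more compounds than are shown below. What is called first, only, known or untested is meant among the compounds shown, and "the series" means these compounds.

Of the compounds shown here, two have so far been measured in a functional assay on HEK293 cells for agonist activity at nuclear receptor subfamily 1 group D member 1 (Homo sapiens), read by a luciferase reporter, with a stated time of 24 h; on this read-out lower numbers stand for an effect already at smaller amounts and higher numbers for an effect only at larger amounts of compound. Compound 1 `O=[N+]([O-])c1ccc(CN(Cc2ccc(Cl)cc2)CC2CCCCC2)s1` gives 7400 nM in this assay, and compound 2 `C=CCOC(=O)N1CCC(CN(Cc2ccc(Cl)cc2)Cc2ccc([N+](=O)[O-])s2)C1` gives 670 nM. For the measured compounds named here, of these two numbers compound 2 holds the lower one, and its only neighbour, compound 1, stands beyond the usual scatter from it. Compound 3 `O=[N+]([O-])c1ccc(CN(Cc2ccc(Cl)cc2)CC2CCN(S(=O)(=O)Cc3ccccc3)C2)s1` has not yet been measured. It differs from compound 2 in a single place: benzylsulfonyl in place of allyloxycarbonyl on an amine nitrogen in a ring. Going by the values given here, no pair of measured compounds shows this particular exchange, so its effect in this assay cannot be read from the numbers at hand; the only known gap, that between compound 1 and compound 2, concerns a different part of the molecule. The expected step is therefore a 1.3-fold lower number from compound 2 to compound 3 (0.13 log units; within the scatter), estimated to stay close to the scatter and, if anything, to lean toward a lower number. The estimate for compound 3 in this assay is 500 nM, with a range from 150 nM to 1500 nM.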

Compound 3, half-maximal effective concentration: 630 nM
Compound 3: middle estimate off by 1.3-fold (0.10 log units), on the low side; low and high end bracket the measured number.
By their numbers in this assay, from the lowest: compounds 3 and 2 (each within the scatter of the next); then compound 1.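

For the compounds shown here, putting benzylsulfonyl in place of allyloxycarbonyl on an amine nitrogen in a ring gives, in this assay, a 1.1-fold lower number from compound 2 to compound 3 (0.03 log units; within the scatter) and thus the first reading of a change at this position: the two compounds cannot be told apart on this read-out. The entering group has more heavy atoms than the one it replaces and brings a six-membered aromatic ring of carbon only, yet neither feature separates compound 3 from compound 2 here, and this single pair shows that the allyloxycarbonyl group is not needed for a number in this range. The two groups have the same counts of hydrogen-bond donors and acceptors, and nothing available explains the outcome.

Since the sulfonyl link and the benzyl ring enter together, the exchange does not show what each contributes alone, so a methylsulfonyl or a benzoyl group on the same nitrogen would help to separate them. Going by these compounds, how this position responds to something much smaller, such as an acetyl or methyl group, or to a free ring amine or a group bearing a carboxylic acid, remains open.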